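A few compounds are considered here, and "the series" means these few. Any claim that something is new, unique, unknown or untested is made for them only; others in the source may bear on it.

Three compounds have been measured in a functional assay on SNB-75 cells (Homo sapiens) for inhibition, read by sulforhodamine B assay, with a stated time of 48 h; on this read-out higher numbers stand for weaker inhibition of growth and lower numbers for stronger inhibition of growth:

Compound 1 `COc1cc(OC)cc(-c2ccc(-c3ccc(C(=N)N)c(F)c3)s2)c1`, 1300 nM
Compound 2 `N=C(N)c1ccc(-c2ccc(-c3ccc(Cl)cc3)s2)cc1F`, 165 nM
Compound 3 `N=C(N)c1ccc(-c2ccc(-c3ccc(Cl)cc3)s2)cc1`, 157 nM

Compound 1 has the highest number of the three; the numbers for compound 2 and compound 3 lie close to each other. Between compound 2 and compound 3 one change is made, (hydrogen in place of fluoro on an aromatic carbon), and it produced a 1.1-fold lower number from compound 2 to compound 3 (0.02 log units; within the scatter). How the core of compound 1 differs from the core of compound 2 is not broken down here.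

Compound 4 `COc1cc(OC)cc(-c2ccc(-c3ccc(C(=N)N)cc3)s2)c1` has not yet been measured in this assay. It arises from compound 1 by the same change, (hydrogen in place of fluoro on an aromatic carbon), made at the same kind of place. Because compound 2 and compound 3 showed a 1.1-fold lower number from compound 2 to compound 3 (0.02 log units; within the scatter), compound 4 is expected to sit close to compound 1, with an estimated step of a 1.1-fold lower number from compound 1 to compound 4 (0.03 log units; within the scatter). The estimate for compound 4 is 1200 nM, between 500 nM and 3000 nM.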

Compound 4, concentration for 50% growth inhibition: 1580 nM
Estimate against measurement, compound 4: 1.3-fold (0.12 log units) below; measured number inside the range.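

In this assay, putting hydrogen in place of fluoro on an aromatic carbon of the core of compound 1 gave a step within the scatter (a 1.2-fold higher number from compound 1 to compound 4 (0.08 log units; within the scatter)). This pair and the earlier one do not show that the fluoro makes no difference on every core or in any other assay, since two pairs set no general rule. What they do show is that the change carried over from one core to the other without a readable difference: the same change on two cores in this assay, a 1.1-fold lower number (0.02 log units; within the scatter) from compound 2 to compound 3 and a 1.2-fold higher number (0.08 log units; within the scatter) from compound 1 to compound 4, 1.3-fold (0.11 log units) apart, within the scatter of two such steps

The compounds shown leave open whether a nitrile or a hydroxyl group on that aromatic carbon would give a step beyond the scatter. They also leave open whether the same change would carry over to a core bearing a carboxylic acid.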